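The source may hold more compounds than are shown below. What is called first, only, known or untested is meant among the compounds shown, and "the series" means these compounds.

Measured in a functional assay on Hep 3B2 cells (Homo sapiens) for antiproliferative activity, read by MTT assay, with a stated time of 24 h, tested at 0.02 ug/mL; on this read-out higher numbers stand for a stronger effect at the one concentration tested and lower numbers for a weaker effect:
compound 1, `CCc1ccc2nc(C(=O)Nc3c(F)cc(-c4cccc(F)c4)cc3F)c(C)c(O)c2c1`, gives 2.05%
compound 2, `CCOc1ccc2nc(C(=O)Nc3c(F)cc(-c4cccc(F)c4)cc3F)c(C)c(O)c2c1`, gives -0.32%
compound 3, `CCc1ccc2nc(C(=O)Nc3c(F)cc(-c4cccc(F)c4)cc3F)c(C)c(C(=O)O)c2c1`, gives -0.05%

All three numbers sit close together. Compound 3 lies within the scatter of compound 2, the nearest to it, and also within the scatter of compound 1, the furthest from it; the step of a number 2.1 percentage points lower from compound 1 to compound 3 (within the scatter) is within the scatter, so the carboxy in place of hydroxy on an aromatic carbon leaves the read-out unchanged as far as can be told. Compound 4, `CCOc1ccc2nc(C(=O)Nc3c(F)cc(-c4cccc(F)c4)cc3F)c(C)c(C(=O)O)c2c1`, has not been measured. It differs from compound 3 by ethoxy in place of ethyl on an aromatic carbon. For the measured compounds named here, the one measured step that bears on this change is a number 2.4 percentage points lower from compound 1 to compound 2 (within the scatter), also within the scatter, where the same exchange of ethoxy for ethyl on the same aromatic carbon was made on the hydroxy-bearing core. On that basis no step beyond the scatter is expected from compound 3 to compound 4 in this assay, and the expected step is a number 2 percentage points lower from compound 3 to compound 4 (within the scatter). Compound 4 is therefore estimated to give about -2% in this assay, with a range from -12% to 8%.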

Compound 4, a percentage reported as inhibition, at one concentration (the size of the read-out at that concentration, not a potency): 0.05%
The estimate for compound 4 lay 2.1 percentage points below the measured number, and the stated range covers the measured number.
By their numbers in this assay, from the lowest: compounds 2, 3, 4 and 1 (each within the scatter of the next).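

In this assay, the exchange of ethoxy for ethyl on the aromatic carbon, until now read only on the hydroxy-bearing core, gives a number 0.1 percentage points higher from compound 3 to compound 4 (within the scatter) on the carboxy-bearing core, so this position shows no step beyond the scatter on either core: the same change on two cores in this assay, a number 2.4 percentage points lower (within the scatter) from compound 1 to compound 2 and a number 0.1 percentage points higher (within the scatter) from compound 3 to compound 4, 2.5 percentage points apart, within the scatter of two such steps

The exchange of carboxy for hydroxy, until now read only with ethyl at this position, can also be read with ethoxy there, where it gives a number 0.4 percentage points higher from compound 2 to compound 4 (within the scatter): the same change on two cores in this assay, a number 2.1 percentage points lower (within the scatter) from compound 1 to compound 3 and a number 0.4 percentage points higher (within the scatter) from compound 2 to compound 4, 2.5 percentage points apart, within the scatter of two such steps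

Together the four compounds form a closed square of changes in which no step leaves the scatter, and the effect of either change does not visibly depend on the other at the one concentration tested.

On these data alone, with all four numbers this close together, the read-out does not yet separate any of these groups, so it remains open whether an amine or a longer chain such as butoxy at this position would give a step beyond the scatter. As far as these compounds go, it is also open whether a primary amide or a methyl ester in place of the carboxy group would do so, and whether these compounds would differ at a higher concentration.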